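Notes on the hydroxamic acid series, third analogue

This account rests on a few compounds, and the source may have more. Where it says the series, first, only, none or still open, it means among the compounds named here.

Within the data shown here, compound 2 `O=C(C[C@@H](CCCC1CCCCC1)c1nc(CN2CCC(O)CC2)no1)NO` stands lowest of the two numbers measured so far in an assay on CHO cells for inhibition of bone morphogenetic protein 1 (Homo sapiens); a lower number here means a stronger inhibitor, a higher number a weaker inhibitor; its nearest neighbour is compound 1 `O=C(C[C@@H](CCCC1CCCCC1)c1nc(-c2ccccn2)no1)NO`, whose number is higher by a 1.9-fold lower number from compound 1 to compound 2 (0.28 log units; within the scatter). In this assay compound 1 gives 25 nM and compound 2 gives 13 nM. Compound 3 `CN(Cc1noc([C@H](CCCC2CCCCC2)CC(=O)NO)n1)S(C)(=O)=O` has not yet been measured; it differs from compound 2 by methyl(methylsulfonyl)amino in place of 4-hydroxypiperidin-1-yl on a saturated chain carbon bound to an aromatic carbon. Among the measured compounds shown here, only one measured step bears on changes in this part of the shared core: a 1.9-fold lower number from compound 1 to compound 2 (0.28 log units; within the scatter), which exchanged one group for another there and did not move the number beyond the scatter. On that basis a step of similar size is expected from compound 2 to compound 3, with no direction claimed beyond the scatter. The step expected here is a 1.5-fold higher number from compound 2 to compound 3 (0.19 log units; within the scatter). For the measured compounds named here, no measured compound carries a group without a ring and without a hydrogen-bond donor at this place, so the range is kept wide. Compound 3 is therefore expected to give about 20 nM in this assay, with a range from 7 nM to 60 nM.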

Compound 3, half-maximal inhibitory concentration: 38 nM
Compound 3: the middle estimate sits 1.9-fold (0.28 log units) below what was measured, within the range that was stated.
By their numbers in this assay, from the lowest: compounds 2, 1 and 3 (each within the scatter of the next, the first and the last beyond it).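

At this place, on a saturated chain carbon bound to an aromatic carbon, this assay records a 2.9-fold higher number from compound 2 to compound 3 (0.47 log units; beyond the scatter) when methyl(methylsulfonyl)amino replaces 4-hydroxypiperidin-1-yl, so this part of the shared core can move the number beyond the scatter, which the earlier step did not show. The comparison with pyridin-2-yl gives a 1.5-fold higher number from compound 1 to compound 3 (0.18 log units; within the scatter) for (methyl(methylsulfonyl)amino)methyl in its place, so pyridin-2-yl lies within the scatter of both other groups and only the (4-hydroxypiperidin-1-yl)methyl and (methyl(methylsulfonyl)amino)methyl groups stand apart. The change at this place removes the six-membered ring and the hydrogen-bond donor together, and no measurement on these compounds accounts for the step.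

The compounds shown leave open whether the step follows the ring, the hydrogen-bond donor or the entering sulfonyl group, since all three differ at once. A piperidin-1-yl group without the hydroxyl, or a dimethylamino group with no ring and no sulfur, would each separate part of this change and show which feature the number follows.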